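The source may hold more compounds than are shown below. What is called first, only, known or untested is meant among the compounds shown, and "the series" means these compounds.

Compound 1 `Cc1ccc2[nH]c(=O)c(/C=N/Nc3ccc([N+](=O)[O-])cc3)cc2c1` and compound 2 `O=c1[nH]c2ccccc2cc1/C=N/Nc1ccc([N+](=O)[O-])cc1` share one core; compound 3 `Cc1ccc2[nH]c(=O)c(/C=N/Cc3ccccc3)cc2c1` and compound 4 `O=c1[nH]c2ccccc2cc1/C=N/Cc1ccccc1` share another, and the difference between the two cores is not broken down here. In a functional assay, read by spectrophotometry, with a stated time of 30 min (on this read-out lower numbers stand for stronger inhibition and higher numbers for weaker inhibition), compound 1 gives 109000 nM. In this assay compound 2 gives 170000 nM. The change from compound 1 to compound 2 is hydrogen in place of methyl on an aromatic carbon and it makes a 1.6-fold higher number from compound 1 to compound 2 (0.19 log units; within the scatter). The same change, (hydrogen in place of methyl on an aromatic carbon), takes compound 3 to compound 4; it occurs twice among these compounds. For compound 3 in this assay no number is reported; compound 3 is recorded as "not active" (no number reported). Compound 4 has not been measured in this assay. For the measured compounds named here, because a 1.6-fold higher number from compound 1 to compound 2 (0.19 log units; within the scatter) is the only measured instance of this change, the same step from compound 3 to compound 4 is expected to be of similar size, so compound 4 is expected to remain near the inactive end where compound 3 sits, and a result reported only as inactive is the most likely outcome. Compound 4 is estimated in this assay at 300000 nM, with an expected range from 120000 nM to 1000000 nM.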

Compound 4, half-maximal inhibitory concentration: "not active" (no number reported)
Compound 4 has no reported number here; the estimate stays without a comparison.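

In this assay compound 3 and compound 4 are both recorded as not active, with no number, and no new step can be read between them. No evidence bears on this result. The compounds shown leave open what size, if any, the change from methyl to hydrogen has on the core of compound 3.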